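Removing One Fluoro Group From Compound 2

The compounds below may be only part of what the source reports. "The series", "measured", "known", "first", "only" and "open" are said of these compounds alone.

Values measured in an ADME assay on H9c2 cells (Rattus norvegicus) for cytotoxicity, read by MTT assay, with a stated time of 48 h (a higher number here means a weaker inhibitor, a lower number a stronger inhibitor), are these:
Compound 1 `COc1ccc(NC(=S)OCCNC(=O)C(C)(C)Oc2ccc(Cl)cc2)cc1` gives 747000 nM as a measured number
Compound 2 `O=C(NCCOC(=S)Nc1ccc(F)cc1)c1cccnc1` gives > 800000 nM as a limit

Compound 2 stands at the limit of > 800000 nM in this assay, at which 1 of the 2 values shown sits, and this reading is a limit, not a number. Compound 3 `O=C(NCCOC(=S)Nc1ccccc1)c1cccnc1` differs from compound 2 in one place hydrogen in place of fluoro on an aromatic carbon with hydrogen in place of fluoro on an aromatic carbon, so 4-fluorophenyl becomes phenyl. Compound 1 differs from compound 2 in more than one place, so that pair offers no clean comparison. For the measured compounds named here, no measured pair shows this change on its own, and no step beyond the usual scatter is expected in this assay in either direction. The expected move a number no higher from compound 2 to compound 3 (the limit leaves the size open) is small in this estimate, and the reading may again be only a limit. Compound 3 is estimated at 800000 nM with an expected range from 350000 nM to 1500000 nM in the coming measurement.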

Compound 3, half-maximal inhibitory concentration: > 800000 nM
Compound 3: only a limit was reported; the forecaster's own chance of this, stated with the estimate: 60%; the middle value sits exactly at the limit.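

No step can be read from compound 2 to compound 3 in this assay because each reading is a limit and not a number: the limit of > 800000 nM in this assay, at which 2 of the 3 values shown sit. From the compounds shown here alone, whether going from 4-fluorophenyl to phenyl changes the cytotoxicity at all therefore stays open.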